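The source may hold more compounds than are shown below. What is called first, only, known or untested is meant among the compounds shown, and "the series" means these compounds.

Measured compounds:
compound 1, `COc1ccc(C(=O)/C=C/c2cc3ccccc3[nH]c2=O)cc1` — 4380 nM in a functional assay on UACC-62 cells (Homo sapiens) for cytotoxicity, read by sulforhodamine B assay, with a stated time of 24 h; on this read-out lower numbers stand for stronger inhibition of growth and higher numbers for weaker inhibition of growth
compound 2, `O=C(/C=C/c1cc2ccccc2[nH]c1=O)c1ccc(O)cc1` — 2880 nM

Compound 2 has the lowest number of the two measured compounds in this assay. Within the data shown here, its only neighbour is compound 1, and the step from one to the other, a 1.5-fold lower number from compound 1 to compound 2 (0.18 log units; within the scatter), is within the scatter, so the two values cannot be told apart.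

Compound 3, `O=C(/C=C/c1cc2ccccc2[nH]c1=O)c1ccc(Cl)cc1`, has not yet been measured. It differs from compound 2 in one place: chloro in place of hydroxy on an aromatic carbon, on an aromatic carbon of a six-membered aromatic ring of carbon only, para to a large group; cut one bond further out, the difference reads 4-hydroxyphenyl to 4-chlorophenyl.

Among the measured compounds shown here, the only measured step at this position, the change from compound 1 to compound 2, swaps one oxygen-bearing group for another and stays within the scatter. For the measured compounds named here, no measured step shows what a chloro group does here, so there is no basis for expecting a change beyond the scatter. The estimate for compound 3 is a step of a 1.0-fold higher number from compound 2 to compound 3 (0.02 log units; within the scatter), giving an expected value of 3000 nM, with a range from 1000 nM to 9000 nM.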

Compound 3, concentration for 50% growth inhibition: 5710 nM
The estimate for compound 3 lay 1.9-fold (0.28 log units) below the measured number; the range from low to high includes it.
By their numbers in this assay, from the lowest: compounds 2, 1 and 3 (each within the scatter of the next).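

In this assay, chloro in place of hydroxy gives a 2.0-fold higher number from compound 2 to compound 3 (0.30 log units; within the scatter) and chloro in place of methoxy gives a 1.3-fold higher number from compound 1 to compound 3 (0.12 log units; within the scatter) on the same aromatic carbon. Among these compounds, this is the first look at a group on this carbon that has no oxygen: chloro counts no hydrogen-bond donor and no hydrogen-bond acceptor, whereas hydroxy counts one of each, yet the values of all three compounds still cannot be told apart. Among these three compounds, then, the choice between hydroxy, methoxy and chloro at this position makes no difference that this measurement can resolve, and nothing measured independently bears on this result.

The compounds shown leave open whether a quite different group on this carbon, such as an amine, a carboxylic acid or a longer chain like butoxy, would move the number beyond the scatter. Among the compounds shown here, they also leave open what a group on another carbon of this ring would do, since all three compounds carry their single group at the same place.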